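This account rests on a few compounds, and the source may have more. Where it says the series, first, only, none or still open, it means among the compounds named here.

Measured so far:
compound 1 `Cn1c(-c2ccc(NC(=O)CSc3nc4ccccc4o3)cc2)nc(-c2ccccc2)c1-c1ccccc1` – 76.3%
compound 2 `Cn1c(-c2ccc(NC(=O)CSc3nc4ccccc4s3)cc2)nc(-c2ccccc2)c1-c1ccccc1` – 76.6%
compound 3 `Cn1c(-c2ccc(NC(=O)CSC3=NCCS3)cc2)nc(-c2ccccc2)c1-c1ccccc1` – 70%

In a functional assay on MCF7 cells (Homo sapiens) for cytotoxicity, read by MTT assay, with a stated time of 24 h, tested at 80 ug/mL (a higher number here means a stronger effect of the compound at the concentration tested, a lower number a weaker effect), compound 1 stands second highest of these three numbers, though its step to compound 2 a number 0.3 percentage points higher from compound 1 to compound 2 (within the scatter) and its step to compound 3 a number 6.3 percentage points lower from compound 1 to compound 3 (within the scatter) both lie within the scatter, so the three cannot be ranked. Compound 4 `CN(C)/C=C/N1CCN(CC(=O)Nc2ccc(-c3nc(-c4ccccc4)c(-c4ccccc4)n3C)cc2)CC1` has not been measured. Its change from compound 1 is 4-(2-(dimethylamino)ethenyl)piperazin-1-yl in place of (1,3-benzoxazol-2-yl)sulfanyl on a saturated chain carbon bound to a carbonyl carbon. The measured steps all swap one sulfur-bound ring for another; none replaces the whole sulfanyl group as this change does, so they give only weak guidance. Since every ring swap so far left the read-out within scatter, compound 4 is expected to give 65%, between 40% and 82%, a step of a number 11.3 percentage points lower from compound 1 to compound 4 (beyond the scatter).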

Compound 4, a percentage reported as activity, at one concentration (the size of the read-out at that concentration, not a potency): 34.7%
The estimate for compound 4 lay 30.3 percentage points above the measured number; the whole stated range lies above it.
By their numbers in this assay, from the lowest: compound 4; then compounds 3, 1 and 2 (each within the scatter of the next).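

In this assay, the saturated chain carbon bound to a carbonyl carbon proves sensitive to what it carries: swapping one sulfur-bound ring for another left the read-out within the scatter, but replacing the whole sulfanyl group with 4-(2-(dimethylamino)ethenyl)piperazin-1-yl gives a number 41.6 percentage points lower from compound 1 to compound 4 (beyond the scatter), a number 41.9 percentage points lower from compound 2 to compound 4 (beyond the scatter) and a number 35.3 percentage points lower from compound 3 to compound 4 (beyond the scatter). So this change reaches much further than the ring swaps did. No measurement available here explains the fall.

Which part of the new group matters remains open. A plain piperazin-1-yl or a dimethylamino group on that carbon would help separate the ring from the ethenyl tail.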